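This account rests on a few compounds, and the source may have more. Where it says the series, first, only, none or still open, it means among the compounds named here.

In a functional assay for inhibition, with Homo sapiens as the target (a higher number here means a weaker inhibitor, a lower number a stronger inhibitor), compound 1 `Cc1cccc(Nc2nccc(-c3cccs3)n2)c1` gives 300 nM, compound 2 `Cc1ccc(-c2ccnc(Nc3cccc(N(C)C)c3)n2)s1` gives 5700 nM, and compound 3 `COc1cccc(Nc2nccc(-c3ccsc3)n2)c1` gives 1800 nM. Among these three numbers compound 3 stands second highest: its nearest neighbour is compound 2, whose number lies higher by a gap beyond the usual scatter, and its furthest is compound 1, whose number lies lower, also beyond the scatter. Compound 4 `COc1cccc(Nc2nccc(-c3cc(C)oc3C)n2)c1` has not yet been measured. Going by the values given here, it differs from compound 3 in one place: 2,5-dimethylfuran-3-yl in place of thiophen-3-yl on an aromatic carbon No step of this kind has been measured among the known compounds, so its size is open. The expectation for compound 4 is a modest shift, a 1.4-fold higher number from compound 3 to compound 4 (0.14 log units; within the scatter), toward a slightly weaker inhibitor, not far beyond the scatter. Compound 4 is therefore estimated at 2500 nM, between 800 nM and 8000 nM.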

Compound 4, half-maximal inhibitory concentration: 5800 nM
Compound 4: middle estimate off by 2.3-fold (0.37 log units), on the low side, within the range that was stated.
By their numbers in this assay, from the lowest: compound 1; then compound 3; then compounds 2 and 4 (each within the scatter of the next).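

In this assay, this step gives a one-place comparison on this aromatic carbon of the six-membered ring: 2,5-dimethylfuran-3-yl in place of thiophen-3-yl gives a 3.2-fold higher number from compound 3 to compound 4 (0.51 log units; beyond the scatter). The position therefore responds to the choice of ring, toward a weaker inhibitor, even though both groups are five-membered aromatic rings with one hetero atom. No available evidence accounts for this step. Open, as far as these compounds go, is whether the two methyl groups or the change from sulfur to oxygen carries the shift, which plain furan-3-yl or 2,5-dimethylthiophen-3-yl would separate. From the compounds shown here alone, how an amine on the five-membered ring would read also remains open.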